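Cyclohexyl amide in place of a basic amine side chain

The source may report more compounds than this note shows. Statements on the series, on what has been measured and on what is new or still open speak of the compounds shown alone.

The series shares a core carrying a methoxyphenyl group and a trifluoromethylphenyl group, differing only in the amide part. Compound 1 is `COc1cccc(-c2cn(-c3ccc(C(F)(F)F)cc3)nc2C(=O)N2CCc3ccccc3C2)c1`. In a functional assay on BMDM cells (Mus musculus, strain C57BL/6) for inhibition, with a stated time of 2 days (a higher number here means a weaker inhibitor, a lower number a stronger inhibitor), compound 1 gives > 30000 nM, which is a limit of the assay and not a number. Compound 2 is `COc1cccc(-c2cn(-c3ccc(C(F)(F)F)cc3)nc2C(=O)NCCCN(C)C)c1`, with (3-(dimethylamino)propyl)amino in place of 1,2,3,4-tetrahydroisoquinolin-2-yl on a carbonyl carbon. In this assay compound 2 gives > 30000 nM, again a limit rather than a number. The step that the two limits leave unreadable from compound 1 to compound 2 therefore cannot be read. Both values sit at the limit of > 30000 nM in this assay, at which 2 of the 2 values shown sit, so compound 2 stands only at a limit, and nothing in these two compounds shows a measurable inhibitor.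

Compound 3 is `COc1cccc(-c2cn(-c3ccc(C(F)(F)F)cc3)nc2C(=O)NC2CCCCC2)c1`. It differs from compound 2 by cyclohexyl in place of 3-(dimethylamino)propyl on an amide-type nitrogen. Going by the values given here, no measured step bears on this change, since the one step known is unreadable. He therefore expects no measurable step a number no higher from compound 2 to compound 3 (the limit leaves the size open) and, for compound 3, an estimate of 30000 nM in this assay, most likely again reported as a limit, within 10000 nM to 100000 nM.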

Compound 3, half-maximal inhibitory concentration: > 30000 nM
Compound 3 ended at the assay's limit; the forecaster's own chance of this, stated with the estimate: 80%; the middle value lies on the limit itself.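

In this assay compound 3 gives > 30000 nM as a limit of the assay and not a number. The steps among compound 1, compound 2 and compound 3 therefore cannot be read, as all three sit at the same limit: the limit of > 30000 nM in this assay, at which 3 of the 3 values shown sit. The compounds shown leave open whether any amide on the shared core reaches a measurable value, and how these three amide parts truly compare.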